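Pyrazole amide as successor to the hydroxyphenyl amide

The compounds below may be only part of what the source reports. "The series", "measured", "known", "first", "only" and "open" are said of these compounds alone.

Measured compounds in a toxicity assay on THP-1 cells (Homo sapiens) for inhibition; on this read-out higher numbers stand for lower toxicity in this test and lower numbers for higher toxicity in this test:
compound 1 `Cn1c(-c2ccc(Br)cc2)cnc1NC(=O)c1ccc(F)cc1` gives 46000 nM
compound 2 `COc1ccc(-c2cnc(NC(=O)c3cccc(O)c3)n2C)cc1` gives > 100000 nM
compound 3 `COc1ccc(-c2cnc(NC(=O)c3ccc(F)cc3)[nH]2)cc1` gives > 100000 nM

Compound 2 returns only a limit of the assay, not a number, in this assay. Compound 3 likewise sits at a limit rather than at a number. Within the data shown here, the sole numerical reading in the set belongs to compound 1. Compound 2 thus stands at the top of what has been resolved so far, together with compound 3, and the two limits mean (the limit of > 100000 nM in this assay, at which 2 of the 3 values shown sit).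

The next member, compound 4 `COc1ccc(-c2cnc(NC(=O)c3ccn[nH]3)n2C)cc1`, differs from compound 2 in one place: 1H-pyrazol-5-yl in place of 3-hydroxyphenyl on a carbonyl carbon. Both groups carry the same count of hydrogen-bond donors and acceptors, and neither carries a charge.

Among the measured compounds shown here, no step between measured compounds with a single change is available, so the size of this step can only be anticipated. With compound 2 already at a limit, the expectation in this assay is no step beyond the scatter, in either direction, and a fair chance that compound 4 will again report only a limit. The estimate for compound 4 is 100000 nM, within 40000 nM to 300000 nM. This estimate implies a step of a number no higher from compound 2 to compound 4 (the limit leaves the size open), expected to lie within the scatter.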

Compound 4, half-maximal cytotoxic concentration: > 100000 nM
Compound 4: a limit, no number; the forecaster's own chance of this, stated with the estimate: 65%; the middle value lies on the limit itself.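

In this assay compound 4 gives > 100000 nM, a limit of the assay and not a number. Among these compounds, compound 2 also stands at a limit, so no step between compound 2 and compound 4 can be read. Left open is whether 1H-pyrazol-5-yl and 3-hydroxyphenyl on a carbonyl carbon differ at all on this read-out, as most of the series rests at one limit: the limit of > 100000 nM in this assay, at which 3 of the 4 values shown sit.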